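A Single Aryl Swap on the Shared Core

The source may report more compounds than this note shows. Statements on the series, on what has been measured and on what is new or still open speak of the compounds shown alone.

Compound 1 `COC(=O)c1sc2cc(-c3cccs3)cnc2c1N` shows the highest number of the two compounds measured in a functional assay on NCI-H460 cells (Homo sapiens) for inhibition, read by sulforhodamine B assay, with a stated time of 48 h (a higher number here means a weaker inhibitor of growth, a lower number a stronger inhibitor of growth), giving 18000 nM. Compound 2 `COC(=O)c1sc2cc(-c3ccc(-c4cccs4)s3)cnc2c1N` gives 700 nM in this assay, and the step of a 26-fold lower number from compound 1 to compound 2 (1.41 log units; beyond the scatter) came from adding a further thiophen-2-yl. Compound 3 `COC(=O)c1sc2cc(-c3ccccc3N)cnc2c1N` differs from compound 1 by 2-aminophenyl in place of thiophen-2-yl on an aromatic carbon. For the measured compounds named here, no measured step exchanges one aryl group for another of similar size, so the step from compound 1 to compound 2 bears only loosely on it. The expected change a 1.5-fold lower number from compound 1 to compound 3 (0.18 log units; within the scatter) is therefore small, probably within the scatter. Compound 3 is estimated at 12000 nM, with a range from 3000 nM to 40000 nM.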

Compound 3, concentration for 50% growth inhibition: 3800 nM
Estimate against measurement, compound 3: 3.2-fold (0.50 log units) above; measured number inside the range.
By their numbers in this assay, from the lowest: compound 2; then compound 3; then compound 1.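

In this assay, exchanging one aryl group for another at this position, with no second ring added, still moves the number beyond the scatter: a 4.7-fold lower number from compound 1 to compound 3 (0.68 log units; beyond the scatter). The position therefore responds to the identity of the aryl group as well as to the extension seen with compound 2. No measurement here accounts for this step.

The step changes the ring and adds the amine together, so the compounds shown do not tell which of the two matters. A plain phenyl group, or a hydroxyl in place of the amine, would separate them.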